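Series notes: acetyl in place of hexyl on the aromatic carbon

This account rests on a few compounds, and the source may have more. Where it says the series, first, only, none or still open, it means among the compounds named here.

For the measured compounds named here, compound 3 `CCCCCCc1cncc(OC[C@@H]2CCCN2C)c1` gives 0.32 nM in an assay on membranes from brain for displacement of a labelled ligand from Neuronal acetylcholine receptor; alpha4/beta2 (Rattus norvegicus) (a higher number here means a weaker inhibitor, a lower number a stronger inhibitor), and stands second highest of the three numbers so far. Compound 2 `CN1CCC[C@H]1COc1cncc(Br)c1` gives 0.27 nM in this assay; the gap is a 1.2-fold higher number from compound 2 to compound 3 (0.07 log units; within the scatter). Compound 1 `CN1CCC[C@H]1COc1cncc(C(F)(F)F)c1` gives 1.83 nM and is the furthest from compound 3; the step is a 5.7-fold lower number from compound 1 to compound 3 (0.76 log units; beyond the scatter). Compound 4 `CC(=O)c1cncc(OC[C@@H]2CCCN2C)c1` differs from compound 3 by acetyl in place of hexyl on an aromatic carbon. Going by the values given here, the steps that bear on this change are those in which hexyl enters, a 5.7-fold lower number from compound 1 to compound 3 (0.76 log units; beyond the scatter), and the exchange at the same carbon, a 6.8-fold lower number from compound 1 to compound 2 (0.83 log units; beyond the scatter); no measured step introduces acetyl. The expectation for compound 4 in this assay is a modest rise, a 2.8-fold higher number from compound 3 to compound 4 (0.45 log units; beyond the scatter). Compound 4 is estimated at 0.9 nM, range 0.25 nM to 3.5 nM.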

Compound 4, inhibition constant: 1.19 nM
Beside the measured number, compound 4's estimate is 1.3-fold (0.12 log units) below it, and the stated range covers the measured number.
By their numbers in this assay, from the lowest: compounds 2 and 3 (each within the scatter of the next); then compounds 4 and 1 (each within the scatter of the next).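

In this assay, acetyl at this aromatic carbon gives up the gain seen with hexyl (a 3.7-fold higher number from compound 3 to compound 4 (0.57 log units; beyond the scatter)) and with bromo (a 4.4-fold higher number from compound 2 to compound 4 (0.64 log units; beyond the scatter)), while it remains within the scatter of trifluoromethyl (a 1.5-fold lower number from compound 1 to compound 4 (0.19 log units; within the scatter)). The four groups therefore form two tiers: hexyl with bromo, and acetyl with trifluoromethyl. No measurement shown explains this split.

As far as these compounds go, whether an amine, a carboxylic acid or a shorter alkyl chain such as ethyl at this carbon would join the hexyl and bromo tier remains open. From the compounds shown here alone, it is also open whether the carbonyl or the shorter chain separates acetyl from hexyl.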